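A Methyl Added to a Compound Known Only by a Limit

The source may report more compounds than this note shows. Statements on the series, on what has been measured and on what is new or still open speak of the compounds shown alone.

Of the compounds shown here, two have been tested so far in a functional assay on the whole organism with Mus musculus as the target; a higher number here means that more compound is needed for the effect, a lower number that less compound is needed. Compound 1 (`CCN(c1ccncc1)n1cccc1`) gives > 20 mg/kg, which is a limit of the assay and not a number. Compound 2 (`CN(c1ccncc1)n1cccc1Cl`) gives > 20 mg/kg, which is likewise only a limit. Compound 2 therefore has no measured dose, and the whole record consists of the limit of > 20 mg/kg in this assay, at which 2 of the 2 values shown sit.

The next compound, compound 3 (`CCN(c1ccncc1)n1cccc1Cl`), differs from compound 2 in one place: methyl in place of hydrogen on a saturated chain carbon bound to a nitrogen on an aromatic ring. This is methyl in place of hydrogen on a saturated chain carbon bound to a nitrogen on an aromatic ring, which can also be read as methyl to ethyl. Going by the values given here, no measured step shows what such a change does in this assay, so the direction remains open and no change beyond the scatter is expected. The expectation rests on (the limit of > 20 mg/kg in this assay, at which 2 of the 2 values shown sit). The estimated step that the limit leaves unreadable from compound 2 to compound 3 is accordingly small. For compound 3 the expected value is 25 mg/kg, with an estimated range of 8 mg/kg to 60 mg/kg, and another limit would be no surprise.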

Compound 3, dose for half-maximal effect: > 20 mg/kg
Compound 3 ended at the assay's limit; the forecaster's own chance of this, stated with the estimate: 70%; the middle value is on the limit's open side.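

In this assay compound 3 gives > 20 mg/kg, which is a limit of the assay and not a number. Going by these compounds alone, compound 1 and compound 2 also stand at limits, so no step to compound 3 can be read. The compounds shown leave open what dose any of them needs for half-maximal effect, and whether the methyl or the chloro changes it.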